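The source may report more compounds than this note shows. Statements on the series, on what has been measured and on what is new or still open speak of the compounds shown alone.

Measured so far:
Compound 1, `Cc1cc(-c2nc3ccccc3s2)ccc1N`: < 10 nM
Compound 2, `Nc1ccc(-c2nc3ccccc3s2)cc1C(F)(F)F`: 1500 nM

In a functional assay on MCF7 cells (Breast, Homo sapiens) for inhibition (a higher number here means a weaker inhibitor of growth, a lower number a stronger inhibitor of growth), compound 2 gives 1500 nM, and this is the only plain number shown for the pair. Compound 1 gives < 10 nM, which is a limit of the assay rather than a number, as the note the limit of < 10 nM in this assay, at which 1 of the 2 values shown sits, records. Within the data shown here, the single measured step, an at least 150-fold higher number from compound 1 to compound 2 (2.17 log units; beyond the scatter), is large and runs toward weaker inhibition of growth.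

Compound 3, `Nc1ccc(-c2nc3ccccc3s2)cc1F`, has not been measured. It differs from compound 2 as follows: fluoro in place of trifluoromethyl on an aromatic carbon. The measured step bears on this change only indirectly: it showed that the trifluoromethyl group went with a much higher number than methyl, so taking trifluoromethyl away is expected to move the number back downward, though how far it falls cannot be read from two points. For compound 3 the estimate is 60 nM (range 10 nM to 400 nM), which would mean an expected step of a 25-fold lower number from compound 2 to compound 3 (1.40 log units; beyond the scatter) toward stronger inhibition.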

Compound 3, concentration for 50% growth inhibition: < 10 nM
Compound 3: only a limit was reported (the forecaster's own chance of this, stated with the estimate: 20%); middle value at least 6.0-fold (0.77 log units) from the limit.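

Placing fluoro instead of trifluoromethyl on this aromatic carbon, ortho to an amino group, brings strong inhibition of growth back in this assay, with an at least 150-fold lower number from compound 2 to compound 3 (2.17 log units; beyond the scatter), so of the three groups shown at this place, only trifluoromethyl goes with a weak result. Compound 3 gives < 10 nM, which is a limit of the assay and not a number. Methyl and fluoro therefore cannot be ranked against each other, as the step between compound 1 and compound 3 cannot be read: the limit of < 10 nM in this assay, at which 2 of the 3 values shown sit.

As far as these compounds go, how far past that limit the true values of compound 1 and compound 3 lie remains open. So does the outcome at this same place for chloro, a methoxy group or a longer chain such as ethyl, any of which would show whether the weak result is peculiar to trifluoromethyl.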